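The compounds below may be only part of what the source reports. "The series", "measured", "known", "first", "only" and "open" are said of these compounds alone.

Compound 1 `C=CCOc1ccc(C(=O)Nc2cccc(C)n2)cc1` and compound 2 `C=CCOc1ccc(C(=O)Nc2cccc(CC)n2)cc1` share one core; compound 3 `CCCCCNc1cccc(NC(=O)c2ccc(OCCC)cc2)n1` and the unmeasured compound 4 `CCCCCCNc1cccc(NC(=O)c2ccc(OCCC)cc2)n1` share another, and the difference between the two cores is not broken down here. In an in vitro assay on HEK-tsA201 cells for antagonist activity at Neuronal acetylcholine receptor; alpha4/beta2 (Homo sapiens), read by fluorescence and calcium flux (a lower number here means a stronger inhibitor, a higher number a weaker inhibitor), compound 1 gives 6000 nM, and compound 2 gives 20500 nM. The step of a 3.4-fold higher number from compound 1 to compound 2 (0.53 log units; beyond the scatter) corresponds to methyl in place of hydrogen on a saturated chain carbon bound to an aromatic carbon. For compound 3 this assay reports only a limit, > 100000 nM. Compound 3 thus sits at the limit of > 100000 nM in this assay, at which 1 of the 3 values shown sits, so no number is available for it.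

Compound 4 carries the same kind of change: methyl in place of hydrogen on a saturated chain carbon, five bonds along the chain from a nitrogen on an aromatic ring. The place is not identical: in the first pair the carbon is bound to an aromatic carbon, whereas in the second it lies five bonds along the chain from a nitrogen on an aromatic ring. Compound 4 is expected to remain at or beyond the limit, an estimated step that the limit leaves unreadable from compound 3 to compound 4, because the earlier step of a 3.4-fold higher number from compound 1 to compound 2 (0.53 log units; beyond the scatter) went toward a weaker inhibitor. For compound 4 the estimate in this assay is 150000 nM, between 60000 nM and 400000 nM.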

Compound 4, half-maximal inhibitory concentration: > 100000 nM
Compound 4 gave a limit, no number; the forecaster's own chance of this, stated with the estimate: 85%; the middle value is on the limit's open side.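

In this assay compound 3 and compound 4 each give only a limit, so no new step can be read between them: the limit of > 100000 nM in this assay, at which 2 of the 4 values shown sit.

The compounds shown leave open whether methyl in place of hydrogen at this place on the chain changes inhibition at all, and in which direction.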